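Trading a triazole for a methyl oxazole

The source may hold more compounds than are shown below. What is called first, only, known or untested is meant among the compounds shown, and "the series" means these compounds.

Measured in a physicochemical assay for solubility; on this read-out lower numbers stand for lower solubility and higher numbers for higher solubility:
- compound 1 `O=S(=O)(Nc1nccs1)c1ccc2c(c1)OCC[C@H]2c1ccc(C(F)(F)F)cc1-c1nccs1`: 7000 nM
- compound 2 `O=S(=O)(Nc1nccs1)c1ccc2c(c1)OCC[C@H]2c1ccc(C(F)(F)F)cc1-n1ccnn1`: 154000 nM
- compound 3 `O=C1OCCN1c1cc(C(F)(F)F)ccc1[C@H]1CCOc2cc(S(=O)(=O)Nc3nccs3)ccc21`: 295000 nM

Compound 2, at 154000 nM, sits at the high end of these three numbers. Its value and that of compound 3 lie within the usual scatter of each other, and compound 1 lies far lower than both.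

The next compound is compound 4 `Cc1nc(-c2cc(C(F)(F)F)ccc2[C@@H]2CCOc3cc(S(=O)(=O)Nc4nccs4)ccc32)co1`, not yet measured. It keeps the shared core and changes one group, on an aromatic carbon, ortho to a large group and meta to a trifluoromethyl group: 2-methyl-1,3-oxazol-4-yl in place of 1H-1,2,3-triazol-1-yl (2-methyl-1,3-oxazol-4-yl in place of 1H-1,2,3-triazol-1-yl on an aromatic carbon).

Within the data shown here, only one measured step bears on this place. It is a 22-fold higher number from compound 1 to compound 2 (1.34 log units; beyond the scatter), a large step, beyond the scatter, made by putting the same 1H-1,2,3-triazol-1-yl in place of 1,3-thiazol-2-yl. The entering 2-methyl-1,3-oxazol-4-yl looks closer in kind to the group of compound 1, measured at 7000 nM, than to the group it replaces. Part of that step is therefore expected to be lost again, though not all of it, as this is a different ring and rests on a single comparison.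

The expected move in this assay is a drop beyond the scatter, a 4.4-fold lower number from compound 2 to compound 4 (0.64 log units; beyond the scatter). For compound 4 the estimate is 35000 nM, with an expected range of 10000 nM to 110000 nM.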

Compound 4, solubility: 130000 nM
Compound 4: middle estimate off by 3.7-fold (0.57 log units), on the low side, and the stated range ends below it.
By their numbers in this assay, from the lowest: compound 1; then compounds 4, 2 and 3 (each within the scatter of the next, the first and the last beyond it).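

In this assay the change from 1H-1,2,3-triazol-1-yl to 2-methyl-1,3-oxazol-4-yl gives a 1.2-fold lower number from compound 2 to compound 4 (0.07 log units; within the scatter) at this place, on an aromatic carbon ortho to a large group, so the two rings cannot be told apart on this read-out, although their heavy atoms, hetero atoms and hydrogen-bond acceptors differ. The same oxazole ring stands well apart from the group of compound 1, with a 19-fold higher number from compound 1 to compound 4 (1.27 log units; beyond the scatter) in the same read-out, so the large step seen earlier is not particular to the triazole, and among these three rings only 1,3-thiazol-2-yl goes with the low number. Nothing measured here explains why that one ring stands apart.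

The compounds shown leave open whether the sulfur of the 1,3-thiazol-2-yl group matters or the way the ring is joined to the shared core, since compound 1 and compound 4 differ in both. Going by these compounds, it also remains open how this place would read with the oxazole stripped of its methyl group, or with a group of another kind, such as an amine or a carboxylic acid.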